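Hydroxymethyl in place of chloro on the shared core

The source may hold more compounds than are shown below. What is called first, only, known or untested is meant among the compounds shown, and "the series" means these compounds.

In a functional assay on the whole organism with Mus musculus as the target (on this read-out higher numbers stand for an effect only at larger amounts of compound and lower numbers for an effect already at smaller amounts), compound 1 `CN(c1ccncc1)n1cccc1` gives > 20 mg/kg as a limit. Compound 2 `CN(c1ccncc1)n1cccc1Cl` gives > 20 mg/kg and this too is a limit. Compound 3 `CCCN(c1ccncc1)n1cccc1Cl` gives > 20 mg/kg as a further limit. For the measured compounds named here, the series so far offers only the limit of > 20 mg/kg in this assay, at which 3 of the 3 values shown sit, and compound 2 therefore has no number of its own. The steps a step that the two limits leave unreadable from compound 1 to compound 2 and a step that the two limits leave unreadable from compound 2 to compound 3 give no size to lean on. Compound 4 `CN(c1ccncc1)n1cccc1CO` carries hydroxymethyl in place of chloro on an aromatic carbon, with the change hydroxymethyl in place of chloro on an aromatic carbon as counted. The estimated step that the limit leaves unreadable from compound 2 to compound 4 is expected to show no direction beyond the scatter. In this assay the estimated value for compound 4 is 30 mg/kg with 12 mg/kg to 80 mg/kg as the expected range.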

Compound 4, dose for half-maximal effect: > 20 mg/kg
Compound 4 ended at the assay's limit (the forecaster's own chance of this, stated with the estimate: 70%); the middle value is on the limit's open side.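

For the compounds shown here, no step from compound 1 or compound 2 to compound 4 can be read, as the series offers only: the limit of > 20 mg/kg in this assay, at which 4 of the 4 values shown sit. The compounds shown leave open whether any of these changes on the shared core alters the half-maximal dose in this assay.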